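Ester Chain Length and Stability at the Upper Limit

The source may hold more compounds than are shown below. What is called first, only, known or untested is meant among the compounds shown, and "the series" means these compounds.

Compound 1 `CCOC(=O)C1=C(S[C@@H]2CN[C@H](C(=O)Nc3cccc(C(=O)OCC)c3)C2)[C@H](C)[C@@H]2[C@@H]([C@@H](C)OC(C)=O)C(=O)N12` was examined in an ADME assay for metabolic stability, read by LC-MS, with a stated time of 3 h, at pH 6.5, tested at 50 uM; a lower number here means that less of the compound is left, a higher number that more of the compound is left. In this assay compound 1 gives > 95%, which is a limit of the assay rather than a measured number. A second compound, compound 2 `CC(C)OC(=O)OCOC(=O)C1=C(S[C@@H]2CN[C@H](C(=O)Nc3cccc(C(=O)O)c3)C2)[C@H](C)[C@@H]2[C@@H]([C@@H](C)O)C(=O)N12`, belongs to the same study. In this assay compound 2 gives > 95%, again a limit and not a number. Both results therefore sit at the limit of > 95% in this assay, at which 2 of the 2 values shown sit, so compound 1 stands at the top of what the assay can report, with nothing measured above it.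

Compound 3 `CCOC(=O)C1=C(S[C@@H]2CN[C@H](C(=O)Nc3cccc(C(=O)OCC)c3)C2)[C@H](C)[C@@H]2[C@@H]([C@@H](C)OC(=O)CC)C(=O)N12` has not yet been tested. It differs from compound 1 in one place: methyl in place of hydrogen on a saturated chain carbon bound to a carbonyl carbon. Going by the values given here, no step between measured compounds is available to show how such a change plays out in this assay. Given that compound 1 sits at the limit, the expectation for this assay is a step from compound 1 to compound 3 of a number no higher from compound 1 to compound 3 (the limit leaves the size open), which would be no more than the usual scatter. Compound 3 is therefore expected to give about 95% in this assay, within a range from 85% to 99%.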

Compound 3, percent of the compound remaining: > 95%
Compound 3 was reported as a limit; the forecaster's own chance of this, stated with the estimate: 70%; the middle value lies on the limit itself.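

No step from compound 1 to compound 3 can be read, because both results are limits and not numbers: the limit of > 95% in this assay, at which 3 of the 3 values shown sit.

The compounds shown leave open whether the change from acetoxy to propanoyloxy alters how much compound remains in this assay, since none of the three gives a value below that limit.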